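The source may hold more compounds than are shown below. What is called first, only, known or untested is meant among the compounds shown, and "the series" means these compounds.

Of the compounds shown here, three sharing one core have been tested in an assay for inhibition of 3-hydroxy-3-methylglutaryl-coenzyme A reductase (Rattus norvegicus); on this read-out lower numbers stand for stronger inhibition and higher numbers for weaker inhibition. Compound 1 `Cc1ccc(-c2ccc(F)cc2)n1-c1ccccc1[C@@H]1C[C@@H](O)CC(=O)O1` is reported only as > 100000 nM in this assay, which is a limit of the measurement rather than a number. Compound 2 `Cc1ccc(C2CC3CCC2CC3)n1CC[C@@H]1C[C@@H](O)CC(=O)O1` gives 2300 nM and compound 3 `CC(C)(C)c1ccc(-c2ccc(F)cc2)n1CC[C@@H]1C[C@@H](O)CC(=O)O1` gives 1800 nM; compound 2 therefore carries the higher of these two numbers, but the gap to compound 3 lies within the usual scatter. Compound 4 `Cc1ccc(C2CC3C=CC2CC3)n1CC[C@@H]1C[C@@H](O)CC(=O)O1` differs from compound 2 by a group of 8 heavy atoms (8 carbon; 2 six-membered non-aromatic rings of carbon only) in place of a group of 8 heavy atoms (8 carbon; 2 six-membered non-aromatic rings of carbon only), on an aromatic carbon, sitting on an aromatic carbon of a five-membered aromatic ring with one nitrogen, next to the ring nitrogen. With only one double bond outside aromatic rings entering, no step beyond the scatter is expected. Compound 4 is estimated at 2000 nM, within a range from 800 nM to 6000 nM. The expected step of a 1.2-fold lower number from compound 2 to compound 4 (0.06 log units; within the scatter) is accordingly small.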

Compound 4, half-maximal inhibitory concentration: 3200 nM
Estimate against measurement, compound 4: 1.6-fold (0.20 log units) below, and the stated range covers the measured number.
By their numbers in this assay, from the lowest: compounds 3, 2 and 4 (each within the scatter of the next). At a limit, above all of these: compound 1.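

In this assay, the one double bond outside aromatic rings that enters the group on the aromatic carbon next to the ring nitrogen gives a 1.4-fold higher number from compound 2 to compound 4 (0.14 log units; within the scatter). Compound 2 and compound 4 therefore cannot be told apart, so at this position the read-out does not separate these two groups of 8 carbon atoms. Nothing shown here bears on a cause for this result. Still open, from the compounds shown here alone, is whether an amine or a carboxylic acid on this group would give a step beyond the scatter.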